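This account rests on a few compounds, and the source may have more. Where it says the series, first, only, none or still open, it means among the compounds named here.

Measured compounds:
Compound 1, `O=C1Nc2ccc(F)cc2/C1=N/NC(=S)N1CCN(c2ccccc2)CC1`: 12400 nM
Compound 2, `O=C1Nc2cc(Br)ccc2/C1=N/NC(=S)N1CCN(c2ccccc2)CC1`: 14500 nM
Compound 3, `Cc1ccc(N2CCN(C(=S)N/N=C3\C(=O)Nc4ccc(Cl)cc43)CC2)cc1`: 6390 nM

All three were tested in a functional assay on HCT-116 cells (Homo sapiens) for inhibition, read by MTT assay, with a stated time of 72 h; a lower number here means a stronger inhibitor, a higher number a weaker inhibitor. Among them compound 3 has the lowest number of the three; its nearest neighbour is compound 1, whose number lies within the usual scatter of repeated measurements, so no order between compound 3 and compound 1 can be read from these two values. Compound 2 stands furthest from compound 3, and that gap is beyond the scatter. Within the data shown here, since no two of the measured compounds differ in only one place, no single step can be separated out from these three values.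

Compound 4, `O=C1Nc2ccc(Cl)cc2/C1=N/NC(=S)N1CCN(c2ccc([N+](=O)[O-])cc2)CC1`, has not yet been measured in this assay. It differs from compound 3 in one place: nitro in place of methyl on an aromatic carbon. Among the measured compounds shown here, the shared core of compound 3 and compound 4 is the same, so the nitro replacing the methyl is the only change. For the measured compounds named here, none of the measured compounds carries a nitro, so there is nothing here to anchor the size of this step; the estimate therefore leans on the value of compound 3 alone, 6390 nM. The step from compound 3 to compound 4, a 1.1-fold higher number from compound 3 to compound 4 (0.04 log units; within the scatter), is expected to be small, in either direction or none beyond the scatter. Compound 4 is accordingly estimated at 7000 nM in this assay, with a range from 2500 nM to 20000 nM.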

Compound 4, half-maximal inhibitory concentration: 12000 nM
For compound 4 the middle estimate is 1.7-fold (0.23 log units) below the measured one, within the range that was stated.
By their numbers in this assay, from the lowest: compounds 3, 4, 1 and 2 (each within the scatter of the next, the first and the last beyond it).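

In this assay, among these compounds, the change from 4-methylphenyl to 4-nitrophenyl gives the first step that rests on a single difference, and it amounts to a 1.9-fold higher number from compound 3 to compound 4 (0.27 log units; within the scatter). On this aromatic carbon, para to a large group, a methyl can therefore give way to a nitro, with its additional heavy atoms and two hydrogen-bond acceptors, without a change that can be told apart from the scatter of repeated measurements. No measured finding bears on the size of this step or on what lies behind it.

The compounds shown leave open whether this place stays as undemanding with other groups, such as an amine, a carboxylic acid, a methoxy or a longer alkyl chain, since one pair with one change cannot describe a trend across substituents. They also leave open how the halogen on the shared core contributes, as a plain phenyl partner carrying the chlorine would be needed to tie compound 3 and compound 4 to the fluoro and bromo compounds through single steps.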